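Chain homologation notes: compounds 1 to 4

The source may hold more compounds than are shown below. What is called first, only, known or untested is meant among the compounds shown, and "the series" means these compounds.

Measured so far:
compound 1, `CCC(=O)c1ccc2c(c1)sc(=O)n2CCCCCN1CCCCCC1`: 12.2 nM in an assay on cell membranes for displacement of a labelled ligand from Sigma non-opioid intracellular receptor 1 (Rattus norvegicus); a higher number here means a weaker inhibitor, a lower number a stronger inhibitor
compound 2, `CCCC(=O)c1ccc2c(c1)sc(=O)n2CCCCCN1CCCCCC1`: 16.3 nM in this assay
compound 3, `CCCc1ccc2c(c1)sc(=O)n2CCCN1CCCCCC1`: 1.4 nM in this assay

Compound 1 and compound 2 share one core; compound 2 differs from compound 1 by methyl in place of hydrogen on a saturated chain carbon, two bonds along the chain from a carbonyl carbon and this gave a 1.3-fold higher number from compound 1 to compound 2 (0.13 log units; within the scatter). Compound 3 carries a different core; the difference between the two cores is not broken down here. In this assay compound 3 stands lowest of the three, with both others beyond the scatter from it.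

Compound 4, `CCCCc1ccc2c(c1)sc(=O)n2CCCN1CCCCCC1`, is not yet measured. It differs from compound 3 by methyl in place of hydrogen on a saturated chain carbon, three bonds along the chain from an aromatic carbon. This is the same kind of change as from compound 1 to compound 2, but the place differs: there it sat two bonds along the chain from a carbonyl carbon, here three bonds along the chain from an aromatic carbon. A similarly small step is expected, a 1.3-fold higher number from compound 3 to compound 4 (0.11 log units; within the scatter), resting on a 1.3-fold higher number from compound 1 to compound 2 (0.13 log units; within the scatter) being within the scatter. Compound 4 is therefore estimated at 1.8 nM, expected between 0.8 nM and 4 nM.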

Compound 4, inhibition constant: 2.2 nM
Beside the measured number, compound 4's estimate is 1.2-fold (0.09 log units) below it; low and high end bracket the measured number.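

In this assay the added methyl gave a 1.6-fold higher number from compound 3 to compound 4 (0.20 log units; within the scatter), so on this core too the step stays small. Set beside the earlier step, the change reads alike on the two cores: the same change on two cores in this assay, a 1.3-fold higher number (0.13 log units; within the scatter) from compound 1 to compound 2 and a 1.6-fold higher number (0.20 log units; within the scatter) from compound 3 to compound 4, 1.2-fold (0.07 log units) apart, within the scatter of two such steps. Among these compounds, this rests on only two pairs in one assay, with the change at a different place in each, so it does not show that the change would carry to further cores or to other assays.

The compounds shown leave open whether a chain longer than butyl would keep the step this small. They also leave open what an amine or a carboxylic acid at the end of that chain would do.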